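Thioether variants on a dinitrile core as amine oxidase A inhibitors

This account rests on a few compounds, and the source may have more. Where it says the series, first, only, none or still open, it means among the compounds named here.

The measured compounds and their values:
- compound 1, `N#Cc1ccc(SCc2ccccc2)cc1C#N`, 9020 nM in an assay on microsomes for inhibition of Amine oxidase [flavin-containing] A (Homo sapiens), read by fluorescence and spectrophotometry, with a stated time of 20 min; a higher number here means a weaker inhibitor, a lower number a stronger inhibitor
- compound 2, `N#Cc1ccc(SCCc2ccccc2)cc1C#N`, 7190 nM in this assay
- compound 3, `N#Cc1ccc(SC2CCCC2)cc1C#N`, 2780 nM in this assay

All three share the same core, a benzene ring carrying two nitrile groups and a sulfur, and differ only in the group attached to that sulfur. Compound 1 carries a benzyl group, compound 2 a phenethyl group, and compound 3 a cyclopentyl group. Among the three, compound 3 gives the lowest number in this assay, and its gaps to compound 2 and to compound 1 both lie beyond the usual scatter, so compound 3 is the strongest inhibitor of the three.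

Compound 4, `CC(C)CCSc1ccc(C#N)c(C#N)c1`, has not yet been measured. It differs from compound 3 in one place: isopentyl in place of cyclopentyl on a sulfur. The two groups are of the same size in heavy atoms; the ring is opened into a branched chain. Going by the values given here, no measured pair shows this kind of change, so its effect is not known from these data. Since the two groups match in size, the step from compound 3 to compound 4 is expected to be small, within the scatter or slightly toward a weaker inhibitor, at about a 1.3-fold higher number from compound 3 to compound 4 (0.10 log units; within the scatter). For compound 4 the expected value in this assay is 3500 nM, within a range from 1500 nM to 9000 nM.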

Compound 4, half-maximal inhibitory concentration: 1450 nM
The estimate for compound 4 lay 2.4-fold (0.38 log units) above the measured number, and the stated range ends above it.
By their numbers in this assay, from the lowest: compounds 4 and 3 (each within the scatter of the next); then compounds 2 and 1 (each within the scatter of the next).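

In this assay, opening the cyclopentyl ring into an isopentyl chain on the sulfur gives a 1.9-fold lower number from compound 3 to compound 4 (0.28 log units; within the scatter) and so does not separate the two groups, which shows that a ring at this position is not needed for compound 3's level of inhibition. The comparisons with the phenyl-bearing compounds point the same way: isopropyl in place of phenyl on the chain gives a 5.0-fold lower number from compound 2 to compound 4 (0.70 log units; beyond the scatter) and isobutyl in place of phenyl gives a 6.2-fold lower number from compound 1 to compound 4 (0.79 log units; beyond the scatter), so among these compounds a terminal phenyl is not needed either, and both of its replacements give a stronger inhibitor. No measurement among the data shown accounts for these differences.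

The compounds shown leave open how far this position tolerates other saturated groups, such as a longer chain like n-heptyl or a smaller one like ethyl. They also leave open what an amine or a carboxylic acid at the end of the isopentyl chain would do to inhibition of this enzyme.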